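Replacing the 3-methoxyphenyl group of compound 1

The source may report more compounds than this note shows. Statements on the series, on what has been measured and on what is new or still open speak of the compounds shown alone.

In a functional assay on MCF7 cells (Homo sapiens) for antiproliferative activity, read by MTT assay, with a stated time of 48 h (a lower number here means a stronger inhibitor, a higher number a weaker inhibitor), compound 1 `COc1cccc(-n2cc(COc3ccc(/C=C/C(C)=O)cc3OC)nn2)c1` gives 1800 nM, the lowest of the two numbers available and beyond the usual scatter from the other. Compound 2 `COc1cc(/C=C/C(C)=O)ccc1OCc1cn(-c2ccc(C(F)(F)F)c(C(F)(F)F)c2)nn1`, which also lacks the 3-methoxyphenyl, gives 87400 nM. Compound 3 `COc1cc(/C=C/C(C)=O)ccc1OCc1cn(-c2cc(F)cc(Br)c2)nn1` has not yet been measured in this assay. It has 3-bromo-5-fluorophenyl in place of 3-methoxyphenyl on an aromatic nitrogen. Among the measured compounds shown here, no measured pair differs in one place only, so the expectation rests on these two values alone. With compound 2 at 87400 nM, a move to a higher number, beyond the scatter but short of that value, is expected. The expected step is a 5.0-fold higher number from compound 1 to compound 3 (0.70 log units; beyond the scatter). For compound 3 the estimated value is 9000 nM, with an expected range of 2000 nM to 40000 nM.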

Compound 3, half-maximal inhibitory concentration: 65500 nM
Compound 3: the middle estimate sits 7.3-fold (0.86 log units) below what was measured; the measured number lies above the stated range.
By their numbers in this assay, from the lowest: compound 1; then compounds 3 and 2 (each within the scatter of the next).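

In this assay, among the compounds shown here, 3-bromo-5-fluorophenyl in place of 3-methoxyphenyl on the aromatic nitrogen gives a 36-fold higher number from compound 1 to compound 3 (1.56 log units; beyond the scatter), the first comparison at this position that differs in one place only. For the compounds shown here, the two groups have the same heavy-atom count and the same six-membered aromatic carbon ring, so the large step comes with a change of what the ring carries, not of the heavy-atom count, and the hydrogen-bond acceptor of the leaving group has no counterpart in the entering one. Nothing measured here accounts for the step.

On these data alone, it remains open whether the step follows from losing the methoxy group or from gaining the bromine and fluorine. A phenyl ring carrying a hydroxyl, an ethoxy group or an amine would bear on the first question, and one carrying only bromine or only fluorine on the second.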